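The source may hold more compounds than are shown below. What is called first, only, known or untested is meant among the compounds shown, and "the series" means these compounds.

Measured so far in a functional assay on OVCAR-3 cells (Homo sapiens) for antiproliferative activity, read by MTT assay, with a stated time of 24 h; on this read-out lower numbers stand for stronger inhibition and higher numbers for weaker inhibition:
Compound 1 `Cc1ccccc1C(=O)NNC(=O)c1ccc(NS(=O)(=O)c2cnc(O)nc2O)cc1` gives > 20000 nM, a limit of the assay rather than a number.
Compound 2 `Cc1ccc(C(=O)NNC(=O)c2ccc(NS(=O)(=O)c3cnc(O)nc3O)cc2)cc1` gives > 20000 nM, likewise a limit.
Compound 3 `Cc1ccccc1C(=O)NNC(=O)c1cccc(NS(=O)(=O)c2cnc(O)nc2O)c1` gives > 20000 nM, again a limit.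

Compound 2 differs from compound 1 by 4-methylphenyl in place of 2-methylphenyl on a carbonyl carbon. The step that the two limits leave unreadable from compound 1 to compound 2 cannot be read, since both values are limits; all that can be said is the limit of > 20000 nM in this assay, at which 3 of the 3 values shown sit. The difference between the cores of compound 1 and compound 3 is not broken down here. Compound 4 `Cc1ccc(C(=O)NNC(=O)c2cccc(NS(=O)(=O)c3cnc(O)nc3O)c2)cc1` has not been measured; it differs from compound 3 by 4-methylphenyl in place of 2-methylphenyl on a carbonyl carbon, the same change as from compound 1 to compound 2, at the same place. For this assay the step that the limit leaves unreadable from compound 3 to compound 4 is an estimate only, and it rests on compound 3 sitting at > 20000 nM and on the unreadable a step that the two limits leave unreadable from compound 1 to compound 2. Compound 4 is therefore expected at about 40000 nM, most likely reported as a limit again.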

Compound 4, half-maximal inhibitory concentration: > 20000 nM
Compound 4 gave a limit, no number; the forecaster's own chance of this, stated with the estimate: 85%; the middle value lies beyond the limit too.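

Compound 3 and compound 4 both give only a limit, so no step between them can be read: the limit of > 20000 nM in this assay, at which 4 of the 4 values shown sit.

The compounds shown leave open how 2-methylphenyl and 4-methylphenyl compare where this assay gives actual numbers.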